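Methoxy for Chloro on the Pyridine Ring: Compound 4

The source may hold more compounds than are shown below. What is called first, only, known or untested is meant among the compounds shown, and "the series" means these compounds.

Measured compounds:
Compound 1, `O=C(Nc1cc(-c2ccc(Br)cc2)[nH]n1)c1cccnc1Cl`: 8220 nM
Compound 2, `COc1ncccc1C(=O)Nc1cc(-c2ccc(Br)cc2)[nH]n1`: 11100 nM
Compound 3, `O=C(Nc1cc(-c2ccc(Br)cc2)[nH]n1)c1ccc(Cl)nc1`: 8890 nM

In a functional assay on A-375 cells (Homo sapiens) for antiproliferative activity, read by MTT assay, with a stated time of 48 h (a lower number here means a stronger inhibitor, a higher number a weaker inhibitor), these three compounds sit close together. Compound 1 and compound 3 share the same atoms, joined differently: 6-chloropyridin-3-yl in place of 2-chloropyridin-3-yl on a carbonyl carbon. The step of a 1.1-fold higher number from compound 1 to compound 3 (0.03 log units; within the scatter) shows that this rearrangement changes little.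

The change from compound 1 to compound 2 is methoxy in place of chloro on an aromatic carbon, and it made the step of a 1.4-fold higher number from compound 1 to compound 2 (0.13 log units; within the scatter).

Compound 4, `COc1ccc(C(=O)Nc2cc(-c3ccc(Br)cc3)[nH]n2)cn1`, has not yet been measured. It differs from compound 3 by methoxy in place of chloro on an aromatic carbon. Within the data shown here, this is the same kind of change as the one from compound 1 to compound 2, but not the same: in compound 2 the new group sits ortho to a large group, while in compound 4 it sits para to a large group.

Because the earlier step of a 1.4-fold higher number from compound 1 to compound 2 (0.13 log units; within the scatter) stayed within the scatter, a similar outcome is expected for compound 4, with a step of about a 1.3-fold higher number from compound 3 to compound 4 (0.11 log units; within the scatter). Compound 4 is therefore estimated to give 11500 nM in this assay, most likely between 5500 nM and 24000 nM.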

Compound 4, half-maximal inhibitory concentration: 8950 nM
For compound 4 the middle estimate is 1.3-fold (0.11 log units) above the measured one; measured number inside the range.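

In this assay, methoxy in place of chloro gives a 1.0-fold higher number from compound 3 to compound 4 (0.00 log units; within the scatter), so on this core too the swap leaves the number within the scatter. Set beside the earlier case, the two results cannot be told apart: the same change on two cores in this assay, a 1.4-fold higher number (0.13 log units; within the scatter) from compound 1 to compound 2 and a 1.0-fold higher number (0.00 log units; within the scatter) from compound 3 to compound 4, 1.3-fold (0.13 log units) apart, within the scatter of two such steps. Across these two cores, then, the swap carries over with no change that can be separated from ordinary variation between repeats, but two pairs cannot show that it would do so on a different core, and they say nothing about why the number stays put.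

The compounds shown leave open what other groups would do at the same ring carbon, such as an amine, a carboxylic acid or a longer chain like butoxy. On these data alone, all four compounds also carry the same bromo group, so it remains open whether the swap would behave the same way with something else there, such as a nitrile.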